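From compound 2 to compound 3: a ring exchange

This account rests on a few compounds, and the source may have more. Where it says the series, first, only, none or still open, it means among the compounds named here.

Measured so far:
compound 1, `CN(C)CCN(CCN(C)C)c1ccc(C(=O)N2CCc3ccc(OS(N)(=O)=O)cc3C2)cc1`: 3.8%
compound 2, `CCN(Cc1cccnc1)c1ccc(C(=O)N2CCc3ccc(OS(N)(=O)=O)cc3C2)cc1`: 35.7%

In an assay on HEK293 cells for inhibition of Steryl-sulfatase (Homo sapiens), tested at 0.1 uM (on this read-out lower numbers stand for a weaker effect and higher numbers for a stronger effect at the one concentration tested), compound 2 gives 35.7%, the highest of the two numbers; its nearest neighbour is compound 1, which lies a number 31.9 percentage points higher from compound 1 to compound 2 (beyond the scatter). Compound 3, `CCN(Cc1ccc(Br)cc1)c1ccc(C(=O)N2CCc3ccc(OS(N)(=O)=O)cc3C2)cc1`, has not yet been measured. It differs from compound 2 only in that (4-bromophenyl in place of pyridin-3-yl on a saturated chain carbon bound to a nitrogen on an aromatic ring).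

Going by the values given here, the one measured step, from compound 1 to compound 2, exchanges the whole amino substituent and is large, but it does not touch the position altered here, so no measured step bears directly on the change from compound 2 to compound 3. With nothing to point either way, compound 3 is expected to stay close to compound 2, with a step of a number 2.3 percentage points higher from compound 2 to compound 3 (within the scatter) that is not expected to exceed the scatter. The estimate for compound 3 in this assay is 38%, within a range from 15% to 62%.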

Compound 3, a percentage reported as inhibition, at one concentration (the size of the read-out at that concentration, not a potency): 78.2%
Compound 3: middle estimate off by 40.2 percentage points, on the low side; measured number outside the range, above it.
By their numbers in this assay, from the lowest: compound 1; then compound 2; then compound 3.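

In this assay, the ring on the saturated chain carbon bound to a nitrogen on an aromatic ring proves to be a sensitive point: with 4-bromophenyl in place of pyridin-3-yl, the read-out is a number 42.5 percentage points higher from compound 2 to compound 3 (beyond the scatter). Relative to the bis(2-(dimethylamino)ethyl)amino group, the (4-bromobenzyl)(ethyl)amino group gives a number 74.4 percentage points higher from compound 1 to compound 3 (beyond the scatter). No measurement shown here accounts for the gain.

The exchange removes the ring nitrogen and brings in the bromine in a single step, so the compounds shown cannot assign the step to either change. An unsubstituted phenyl ring would separate the two, while 4-chlorophenyl or 4-methoxyphenyl at the same place would show whether bromine itself is needed.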